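Methyl on the alcohol carbon of compound 2

This account rests on a few compounds, and the source may have more. Where it says the series, first, only, none or still open, it means among the compounds named here.

Values in an ADME assay on the whole organism (plasma, strain Sprague-Dawley) for pharmacokinetics, with Rattus norvegicus as the target, with a stated time of 8 h, at a dose of 30 mg/kg by the oral route; a lower number here means less compound in the circulation, a higher number more compound in the circulation at the dose given
compound 1 `CC(=O)Nc1nc(C)c(-c2nc(CC(F)(F)F)no2)s1` gives 1180 ng.h/mL
compound 2 `CC(=O)Nc1nc(C)c(-c2nc(CC(C)(C)CO)no2)s1` gives 92 ng.h/mL

Of the two measured compounds, compound 2 stands lowest at 92 ng.h/mL. Compound 3 `CC(=O)Nc1nc(C)c(-c2nc(CC(C)(C)C(C)O)no2)s1` differs from it in one place: methyl in place of hydrogen on a saturated chain carbon bound to an oxygen on a saturated carbon and a saturated chain carbon. Hydroxymethyl thus becomes 1-hydroxyethyl. Within the data shown here, only one measured step is available, a 13-fold lower number from compound 1 to compound 2 (1.11 log units; beyond the scatter). It is large, but it exchanges a whole group and does not test this methyl. No step beyond the scatter is therefore expected, with a slight lean towards a higher number. The expected change is a 1.3-fold higher number from compound 2 to compound 3 (0.12 log units; within the scatter). For compound 3 the estimated value is 120 ng.h/mL, with an expected range of 45 ng.h/mL to 350 ng.h/mL.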

Compound 3, area under the concentration-time curve: 10900 ng.h/mL
Compound 3: the middle estimate sits 91-fold (1.96 log units) below what was measured, and the stated range ends below it.
By their numbers in this assay, from the lowest: compound 2; then compound 1; then compound 3.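

Methyl on the alcohol carbon gives a 120-fold higher number from compound 2 to compound 3 (2.07 log units; beyond the scatter) in this assay and so makes this position highly sensitive to a single added carbon. Against trifluoromethyl, 2-hydroxy-1,1-dimethylpropyl gives a 9.2-fold higher number from compound 1 to compound 3 (0.97 log units; beyond the scatter) in this assay, so a hydroxyl-bearing chain does not in itself bring the low number of compound 2. No measurement shown here explains this change.

From the compounds shown here alone, whether ethyl on the same carbon would give a similar number remains open. So does the outcome with a ketone in place of the alcohol.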